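A few compounds are considered here, and "the series" means these few. Any claim that something is new, unique, unknown or untested is made for them only; others in the source may bear on it.

Measured so far in a functional assay on HepG2 cells (Homo sapiens) for cytotoxicity, read by MTT assay, with a stated time of 48 h; on this read-out higher numbers stand for weaker inhibition and lower numbers for stronger inhibition:
Compound 1 `C#CCSc1nnc(CC)n1N1C(=O)c2ccccc2C1=O` gives > 200000 nM in this assay, a limit of the assay.
Compound 2 `C=CCSc1nnc(CC)n1N1C(=O)c2ccccc2C1=O` gives > 200000 nM in this assay, a limit of the assay.
Compound 3 `CCc1nnc(SCC(=O)c2ccc(Cl)cc2)n1N1C(=O)c2ccccc2C1=O` gives > 200000 nM in this assay, a limit of the assay.

Compound 3 therefore stands only at a limit, as do the other two values; all sit at the limit of > 200000 nM in this assay, at which 3 of the 3 values shown sit. The steps a step that the two limits leave unreadable from compound 1 to compound 2, a step that the two limits leave unreadable from compound 1 to compound 3 and a step that the two limits leave unreadable from compound 2 to compound 3 are all unreadable in size and direction, since both ends are limits.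

Compound 4 `CCc1nnc(SC)n1N1C(=O)c2ccccc2C1=O` is the next member: hydrogen in place of (4-chlorophenyl)carbonyl on a saturated chain carbon bound to a sulfur. Within the data shown here, no measured step gives a readable size, so no direction can be taken from them; the only footing is that every value so far lies at the limit. Compound 4 is accordingly expected to give 250000 nM in this assay, with a range of 100000 nM to 600000 nM, most probably again reported as a limit. The step that the limit leaves unreadable from compound 3 to compound 4 is expected to be none beyond the scatter.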

Compound 4, half-maximal inhibitory concentration: > 200000 nM
Compound 4 gave a limit, no number; the forecaster's own chance of this, stated with the estimate: 85%; the middle value does not contradict the limit.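

In this assay compound 4 is again a limit, so its steps from compound 1, compound 2 and compound 3 cannot be read: the limit of > 200000 nM in this assay, at which 4 of the 4 values shown sit.
From the compounds shown here alone, whether any group on a saturated chain carbon bound to a sulfur gives a readable value remains open.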